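A few compounds are considered here, and "the series" means these few. Any claim that something is new, unique, unknown or untested is made for them only; others in the source may bear on it.

Measured so far:
- compound 1 `CCc1ccc(SCc2ccc(/C=C/C(=O)Nc3ccccc3N)cc2)cc1` (3.29%)
- compound 2 `Nc1ccccc1NC(=O)/C=C/c1ccc(CSc2ccc(C(F)(F)F)cn2)cc1` (4.42%)

In a functional assay on HCT-116 cells (Homo sapiens) for inhibition, read by CCK-8 assay, with a stated time of 72 h, tested at 2 uM (on this read-out higher numbers stand for more inhibition of growth at the one concentration tested and lower numbers for less inhibition of growth), compound 2 stands at 4.42%, and compound 1 gives 3.29%. The two cannot be separated: a number 1.1 percentage points higher from compound 1 to compound 2 (within the scatter). Among the measured compounds shown here, both numbers are small, so compound 2 sits with its only measured neighbour and no order can be drawn between them.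

Compound 3 `CC(C)(C)c1ccc(SCc2ccc(/C=C/C(=O)Nc3ccccc3N)cc2)cc1` carries one change relative to compound 2: 4-(tert-butyl)phenyl in place of 5-(trifluoromethyl)pyridin-2-yl on a sulfur. It puts 4-(tert-butyl)phenyl in place of 5-(trifluoromethyl)pyridin-2-yl on a sulfur, with the rest of the structure unchanged. For the measured compounds named here, only one measured step touches this place. Compound 1 carries 4-ethylphenyl on that sulfur, and swapping it for the group in compound 2 gave a number 1.1 percentage points higher from compound 1 to compound 2 (within the scatter). Going by the values given here, no measured compound holds 4-(tert-butyl)phenyl itself, so this evidence is thin, and a surprise cannot be ruled out. Even so, no shift beyond the scatter is expected in this assay. The expected change is a number 0.6 percentage points higher from compound 2 to compound 3 (within the scatter). For compound 3 the estimated value is 5%, with an expected range from 0% to 15%.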

Compound 3, percent growth inhibition at one concentration: 6.66%
For compound 3 the middle estimate is 1.7 percentage points below the measured one; the range from low to high includes it.
By their numbers in this assay, from the lowest: compounds 1, 2 and 3 (each within the scatter of the next).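

Working notes on the group on the sulfur: in this assay, the change to 4-(tert-butyl)phenyl in compound 3 gives a number 2.2 percentage points higher from compound 2 to compound 3 (within the scatter) even though the ring hetero atom and all three fluorine atoms leave, so this all-carbon aryl group and the 5-(trifluoromethyl)pyridin-2-yl group cannot be told apart at the one concentration tested. The series also now has its first step confined to the alkyl group on the aryl ring: tert-butyl in place of ethyl on an aromatic carbon gives a number 3.4 percentage points higher from compound 1 to compound 3 (within the scatter) and likewise separates nothing. No measured property of these groups is available to bear on these small steps.

The compounds shown leave open whether any group on this sulfur can move growth inhibition beyond the scatter, since all three remain indistinguishable in this read-out. An amine, a carboxylic acid or a longer chain in place of tert-butyl on that aromatic carbon would test the position with groups quite unlike the ethyl and tert-butyl seen so far.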